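Estimating Compound 4 from Two Weakly Active Analogues

The source may report more compounds than this note shows. Statements on the series, on what has been measured and on what is new or still open speak of the compounds shown alone.

Measured compounds:
compound 1 `CCOC(=O)Nc1sc(-c2ccc(Cl)cc2)c(-c2ccc(Cl)cc2)c1C(=O)NC1CC1`: 27600 nM
compound 2 `COc1ccc(CNC(=O)c2c(N)sc(-c3ccc(Cl)cc3)c2-c2ccc(Cl)cc2)cc1`: 29500 nM
compound 3 `CS(=O)(=O)Nc1sc(-c2ccc(Cl)cc2)c(-c2ccc(Cl)cc2)c1C(=O)NC1CC1`: "not determined" (no result reported)

Among the compounds with values here, in a functional assay on PC-3 cells (Homo sapiens) for inhibition, read by sulforhodamine B assay, with a stated time of 72 h (on this read-out higher numbers stand for weaker inhibition and lower numbers for stronger inhibition), compound 2 gives 29500 nM, the higher of the two numbers so far, while compound 1 gives 27600 nM, a number that lies within the scatter of compound 2, so the two cannot be ranked against each other. In this assay compound 3 gives "not determined" (no result reported), so it adds nothing to the picture. Both measured values sit in a region of weak inhibition, and nothing in the data points to a direction in which the series moves.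

Compound 4 `Nc1sc(-c2ccc(Cl)cc2)c(-c2ccc(Cl)cc2)c1C(=O)N1CCOCC1` differs from compound 2 in one place: morpholin-4-yl in place of (4-methoxybenzyl)amino on a carbonyl carbon. Within the data shown here, no step between two measured compounds exists that would show how this assay responds to a change at the carbonyl carbon, so the expectation rests only on the two weak values at hand. The step in this assay is expected to be small, perhaps a slight move toward weaker inhibition, but not clearly beyond the scatter; the estimated step is a 1.2-fold higher number from compound 2 to compound 4 (0.07 log units; within the scatter). Compound 4 is therefore expected to give about 35000 nM, with a range from 12000 nM to 100000 nM.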

Compound 4, half-maximal inhibitory concentration: 11700 nM
Beside the measured number, compound 4's estimate is 3.0-fold (0.48 log units) above it; the whole stated range lies above it.
By their numbers in this assay, from the lowest: compound 4; then compounds 1 and 2 (each within the scatter of the next).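

Within the data shown here, the exchange on the carbonyl carbon gives the first step that can be read in this assay and it is a 2.5-fold lower number from compound 2 to compound 4 (0.40 log units; beyond the scatter) which is modest but shows that the number responds to a change at this position. The (4-methoxybenzyl)amino group, with its six-membered aromatic ring of carbon only and its hydrogen-bond donor, is therefore not required for the weak inhibition seen in this pair, as compound 4 carries morpholin-4-yl, which has fewer heavy atoms and no hydrogen-bond donor, and still gives the lower number. No evidence at hand bears on what lies behind this step.

With a single step at this position, the compounds shown leave open which part of the exchange goes with the lower number: the removal of the amide hydrogen, the smaller group, or the non-aromatic ring with its two hetero atoms. They also leave open whether a piperidin-1-yl group, a piperazin-1-yl group or a plain dimethylamino group on the same carbonyl carbon would move the number further or return it toward that of compound 2.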